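A few compounds are considered here, and "the series" means these few. Any claim that something is new, unique, unknown or untested is made for them only; others in the source may bear on it.

Measured compounds in the series:

compound 1: `COc1cc2c(Oc3ccc(NC(=O)c4nnn(-c5ccccc5C)c4C)cc3F)ccnc2cc1OCCCN1CCCC1` — 270 nM
compound 2: `COc1cc2c(Oc3ccc(NC(=O)c4nnn(-c5ccccc5C)c4C)cc3F)ccnc2cc1OCCCN1CCCCC1` — 160 nM

Among the compounds with values here, in a functional assay on MKN-45 cells (Homo sapiens) for cytotoxicity, read by MTT assay, with a stated time of 72 h (a lower number here means a stronger inhibitor, a higher number a weaker inhibitor), compound 2 gives 160 nM, the lowest of the two numbers so far; compound 1 gives 270 nM, and the only measured step, a 1.7-fold lower number from compound 1 to compound 2 (0.23 log units; within the scatter), lies within the scatter, so the two compounds cannot be ordered against each other.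

Compound 3 `COc1cc2c(Oc3ccc(NC(=O)c4nnn(-c5ccccc5C(F)(F)F)c4C)cc3F)ccnc2cc1OCCCN1CCCCC1` is not yet measured in this assay. It differs from compound 2 in one place: trifluoromethyl in place of methyl on an aromatic carbon. Within the data shown here, the single measured step concerns the saturated amine at the end of the chain, not the aromatic ring carrying the methyl, so no measured step bears directly on this change. With nothing to set a direction, the working expectation is a number close to that of compound 2: the step expected from compound 2 to compound 3 is no change at the digits printed from compound 2 to compound 3 (within the scatter), which is not beyond the scatter.

For compound 3 in this assay the estimate is 160 nM, with a range from 60 nM to 450 nM.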

Compound 3, half-maximal inhibitory concentration: 90 nM
For compound 3 the middle estimate is 1.8-fold (0.25 log units) above the measured one, within the range that was stated.
By their numbers in this assay, from the lowest: compounds 3, 2 and 1 (each within the scatter of the next, the first and the last beyond it).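

Within the data shown here, compound 3 gives the first reading at the 2-methylphenyl end of the series, as the earlier step concerned only the saturated amine at the end of the chain. In this assay, the change from 2-methylphenyl to 2-(trifluoromethyl)phenyl, which puts a group of 4 heavy atoms in place of 1 on an aromatic carbon ortho to a large group, is a 1.8-fold lower number from compound 2 to compound 3 (0.25 log units; within the scatter), so this position accepts trifluoromethyl with no loss beyond the scatter, and compound 2 and compound 3 cannot be ordered against each other. No supporting measurement bears on this result, and the data offer no explanation for it.

Open, going by these compounds, is how far this tolerance extends at the same aromatic carbon: a hydrogen, a chlorine, a methoxy or an ethyl group could each be read against the methyl of compound 2, and only a larger step would show whether this position matters to the read-out at all. Also open, on these data alone, is whether trifluoromethyl gives a similar reading with another amine at the end of the chain, such as a pyrrolidine or a morpholine.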